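This account rests on a few compounds, and the source may have more. Where it says the series, first, only, none or still open, it means among the compounds named here.

Measured in a physicochemical assay for solubility, using the shake flask method, in simulated intestinal fluid, measured as kinetic solubility, with a stated time of 2 h, at 25 degrees C, at pH 6.5; a higher number here means a more soluble compound, a lower number a less soluble compound:
Compound 1 `Cc1noc(-c2nc(C)c3c(c2N)C(=O)N(Cc2ccc(F)cc2)C3=O)n1` gives < 5000 nM, which is a limit.
Compound 2 `Cc1noc(-c2nc(C)c3c(c2N)C(=O)N(CC2CCNCC2)C3=O)n1` gives 160000 nM.
Compound 3 `Cc1noc(-c2nc(C)c3c(c2N)C(=O)N(Cc2ccc(OC(F)F)cc2)C3=O)n1` gives < 5000 nM, which is a limit.

Compound 3 therefore has a limit rather than a number, and it is not alone: the limit of < 5000 nM in this assay, at which 2 of the 3 values shown sit.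

Compound 4 `Cc1noc(-c2nc(C)c3c(c2N)C(=O)N(Cc2ccncc2)C3=O)n1` changes one group of compound 3: pyridin-4-yl in place of 4-(difluoromethoxy)phenyl on a saturated chain carbon bound to an amide-type nitrogen in a ring.

Two large steps at this same place are the closest guides: an at least 32-fold higher number from compound 1 to compound 2 (1.50 log units; beyond the scatter) and an at least 32-fold lower number from compound 2 to compound 3 (1.50 log units; beyond the scatter). The other step, a step that the two limits leave unreadable from compound 1 to compound 3, offers no size to work from.

Compound 4 keeps an aromatic ring, unlike compound 2 at 160000 nM, so only part of that large rise is expected in this assay.

The expected move is an at least 4.0-fold higher number from compound 3 to compound 4 (0.60 log units; beyond the scatter).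

For compound 4 the estimated value is 20000 nM, with an expected range from 5000 nM to 80000 nM.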

Compound 4, solubility: 26400 nM
Estimate against measurement, compound 4: 1.3-fold (0.12 log units) below; measured number inside the range.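

In this assay, compound 4 shows that this position has a middle level: an aromatic ring can stay here and the number still clears the limit, with an at least 5.2-fold higher number from compound 3 to compound 4 (0.72 log units; beyond the scatter) and an at least 5.2-fold higher number from compound 1 to compound 4 (0.72 log units; beyond the scatter) as the steps. Pyridin-4-yl still falls short of piperidin-4-yl, with a 6.1-fold lower number from compound 2 to compound 4 (0.78 log units; beyond the scatter) as the step. The two rises are only lower bounds, since they start from a limit rather than a number: the limit of < 5000 nM in this assay, at which 2 of the 4 values shown sit.

As far as these compounds go, whether a plain phenyl ring would also stay at that limit remains open. So does the place of a morpholine ring or a carboxylic acid on this same carbon.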